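A few compounds are considered here, and "the series" means these few. Any claim that something is new, unique, unknown or untested is made for them only; others in the source may bear on it.

Measured compounds in a functional assay on PC-3 cells (Homo sapiens) for antiproliferative activity, read by MTT assay, with a stated time of 48 h; on this read-out lower numbers stand for stronger inhibition and higher numbers for weaker inhibition:
Compound 1, `COc1ccc(N/C=C\C(=O)c2cn(-c3ccccc3)nc2-c2ccc(OC)cc2)cc1`: 13400 nM
Compound 2, `COc1cc(-c2nn(-c3ccccc3)cc2C(=O)/C=C\Nc2ccc(F)cc2)cc(OC)c1OC`: 7700 nM
Compound 3, `COc1cc(-c2nn(-c3ccccc3)cc2C(=O)/C=C\Nc2ccc(C(F)(F)F)cc2)cc(OC)c1OC`: > 50000 nM

For compound 3 the figure > 50000 nM is a limit of this assay and not a measured number; the result is the limit of > 50000 nM in this assay, at which 1 of the 3 values shown sits. Compound 3 therefore stands at the weak end of the three, with no exact value.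

Compound 4, `COc1ccc(N/C=C\C(=O)c2cn(-c3ccccc3)nc2-c2cc(OC)c(OC)c(OC)c2)cc1`, is built from compound 3 by one change: methoxy in place of trifluoromethyl on an aromatic carbon. Going by the values given here, the only measured step touching this position is an at least 6.4-fold higher number from compound 2 to compound 3 (0.81 log units; beyond the scatter), a move toward weaker inhibition when trifluoromethyl entered. Compound 4 removes that trifluoromethyl again, so a lower number in this assay is expected. Compound 1 carries methoxy on the same aromatic ring but a different group on the shared core and gives 13400 nM; compound 2 gives 7700 nM. Against that background compound 4 is estimated at 10000 nM, within 4000 nM to 30000 nM. This estimate amounts to an expected at least 5.0-fold lower number from compound 3 to compound 4 (0.69 log units; beyond the scatter).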

Compound 4, half-maximal inhibitory concentration: 9600 nM
Compound 4: the middle estimate sits 1.0-fold (0.02 log units) above what was measured; measured number inside the range.
By their numbers in this assay, from the lowest: compounds 2, 4 and 1 (each within the scatter of the next). At a limit, above all of these: compound 3.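

In this assay, methoxy in place of trifluoromethyl restores activity, giving an at least 5.2-fold lower number from compound 3 to compound 4 (0.71 log units; beyond the scatter), so on this ring trifluoromethyl now stands apart from both fluoro and methoxy. Methoxy and fluoro cannot be told apart here, with a 1.2-fold higher number from compound 2 to compound 4 (0.10 log units; within the scatter), and 3,4,5-trimethoxyphenyl in place of 4-methoxyphenyl on the shared core also stays within the scatter, with a 1.4-fold lower number from compound 1 to compound 4 (0.14 log units; within the scatter). The reading for compound 3 is a limit of the assay and not a number: the limit of > 50000 nM in this assay, at which 1 of the 4 values shown sits.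

The compounds shown leave open how other groups on this aromatic carbon would behave, such as an amine, a carboxylic acid or a longer chain like butoxy. They also leave open whether trifluoromethyl gives the same loss when the core carries 4-methoxyphenyl instead of 3,4,5-trimethoxyphenyl.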